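A few compounds are considered here, and "the series" means these few. Any claim that something is new, unique, unknown or untested is made for them only; others in the source may bear on it.

Measured so far:
- compound 1 `Cc1ccc2c(C3CCN(CCN4CCN(C(C)C)C4=O)CC3)c[nH]c2c1`: 27 nM
- compound 2 `CC(C)N1CCN(CCN2CCC(c3c[nH]c4cc(Cl)ccc34)CC2)C1=O`: 34 nM

Compound 1 stands at the lowest of the two numbers in an assay on cell membranes for displacement of a labelled ligand from Adrenergic receptor alpha-1 (Rattus norvegicus); a lower number here means a stronger inhibitor, a higher number a weaker inhibitor; the nearest is compound 2, and the difference between them, a 1.3-fold higher number from compound 1 to compound 2 (0.10 log units; within the scatter), is within the scatter, so the two values cannot be ordered.

Compound 3 `Cc1ccc2c(C3CCN(CCN4CCN(C(C)C)C4=O)CC3)cn(-c3ccccc3F)c2c1` is not yet measured. It differs from compound 1 in one place: 2-fluorophenyl in place of hydrogen on an aromatic nitrogen. Among the compounds with values here, the only measured step, a 1.3-fold higher number from compound 1 to compound 2 (0.10 log units; within the scatter), concerns a change on an aromatic carbon of the shared core and says nothing about substitution on the aromatic nitrogen. Within the data shown here, no measured pair bears on the change from hydrogen to 2-fluorophenyl at that position, so the expectation rests on the structural change alone and is wide.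

Given that, a moderate step is expected for compound 3, with a weaker number somewhat more likely than a stronger one, a 2.2-fold higher number from compound 1 to compound 3 (0.35 log units; beyond the scatter). The estimate for compound 3 in this assay is 60 nM, with a range from 10 nM to 400 nM.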

Compound 3, half-maximal inhibitory concentration: 370 nM
Estimate against measurement, compound 3: 6.2-fold (0.79 log units) below; the measured number falls inside the stated range.
By their numbers in this assay, from the lowest: compounds 1 and 2 (each within the scatter of the next); then compound 3.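

In this assay the aromatic nitrogen of the shared core proves to be a position that responds strongly to substitution: 2-fluorophenyl in place of hydrogen gives a 14-fold higher number from compound 1 to compound 3 (1.14 log units; beyond the scatter). Within the data shown here, the only earlier step, chloro in place of methyl on an aromatic carbon, gives a 1.3-fold higher number from compound 1 to compound 2 (0.10 log units; within the scatter) and so showed no sensitivity at the one carbon position it probed; the new step is the first to lie beyond the scatter. The change weakens the compound without abolishing measurable displacement, as compound 3 still gives 370 nM, but nothing available explains the size of this step.

The compounds shown leave open whether the loss follows from any substituent on that nitrogen or is particular to this one, since a methyl group, an unsubstituted phenyl and a longer alkyl chain at the same place would separate these cases. They also leave open whether 2-fluorophenyl on the nitrogen of the chloro compound 2 would produce a step of similar size, which would show whether the effect carries over between the two cores.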